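Shortening the ether tail from butyl to isopropyl

This account rests on a few compounds, and the source may have more. Where it says the series, first, only, none or still open, it means among the compounds named here.

Measured so far:
Compound 1, `CCOCCOC1CCN(c2nc(N)c3cc(OC)c(OC)cc3n2)CC1`, gives 1.81 nM in an assay on brain for displacement of a labelled ligand from Adrenergic receptor alpha-1 (Rattus norvegicus); a lower number here means a stronger inhibitor, a higher number a weaker inhibitor.
Compound 2, `CCCCOCCOC1CCN(c2nc(N)c3cc(OC)c(OC)cc3n2)CC1`, gives 1.03 nM in this assay.

On these two numbers compound 2 stands lowest, with compound 1 nearest at a 1.8-fold lower number from compound 1 to compound 2 (0.24 log units; within the scatter), a gap that does not go beyond the scatter. Compound 3, `COc1cc2nc(N3CCC(OCCOC(C)C)CC3)nc(N)c2cc1OC`, has not yet been measured. It differs from compound 2 by isopropyl in place of butyl on an oxygen on a saturated carbon. Among the compounds with values here, the only measured step that bears on this part of the molecule is the one from compound 1 to compound 2, where the chain on that oxygen grew by ethyl and the number changed by a 1.8-fold lower number from compound 1 to compound 2 (0.24 log units; within the scatter), within the scatter. Isopropyl is larger than ethyl and smaller than butyl, so no step beyond the scatter is expected in this assay. Compound 3 is therefore estimated at 1.3 nM, with a range from 0.6 nM to 3 nM, which would mean a step of a 1.3-fold higher number from compound 2 to compound 3 (0.10 log units; within the scatter).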

Compound 3, inhibition constant: 0.67 nM
Compound 3: the middle estimate sits 1.9-fold (0.29 log units) above what was measured, and the stated range covers the measured number.
By their numbers in this assay, from the lowest: compounds 3, 2 and 1 (each within the scatter of the next, the first and the last beyond it).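

In this assay, isopropyl in place of butyl on this oxygen gives a 1.5-fold lower number from compound 2 to compound 3 (0.19 log units; within the scatter), so this change leaves the number within the scatter. Methyl in place of hydrogen on the saturated chain carbon bound to the oxygen gives a 2.7-fold lower number from compound 1 to compound 3 (0.43 log units; beyond the scatter), the first step at this position to go beyond the scatter, though only a modest one. Nothing available accounts for this difference.

The compounds shown leave open whether a tert-butyl or cyclopropyl group on this oxygen would carry the step further, and whether an amine or a hydroxyl group at the end of the chain would be tolerated. They also leave open how the 2-isopropoxyethyl chain would read at any other receptor.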